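Aryl-piperazine oximes: thiazole for pyrimidine on ring nitrogen

This account rests on a few compounds, and the source may have more. Where it says the series, first, only, none or still open, it means among the compounds named here.

Three analogues of the shared core have been measured. Compound 1 `O/N=C(\CCN1CCN(c2ccccn2)CC1)c1ccccc1` gives 70% in a functional assay on HEK293 cells with D(4) dopamine receptor (Homo sapiens) as the target, read by FLIPR; a higher number here means a larger maximal response, a lower number a smaller maximal response. Compound 2 `N#Cc1cccnc1N1CCN(CC/C(=N\O)c2ccccc2)CC1` gives 64% in this assay, and the step of a number 6 percentage points lower from compound 1 to compound 2 (within the scatter). Compound 3 `O/N=C(\CCN1CCN(c2ncccn2)CC1)c1ccccc1` gives 49% in this assay and stands lowest of the three: the step of a number 21 percentage points lower from compound 1 to compound 3 (beyond the scatter), and the step of a number 15 percentage points lower from compound 2 to compound 3 (beyond the scatter).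

Compound 4 `O/N=C(\CCN1CCN(c2nccs2)CC1)c1ccccc1` differs from compound 3 in one place: 1,3-thiazol-2-yl in place of pyrimidin-2-yl on an amine nitrogen in a ring. Among the compounds with values here, no measured step swaps one five-membered aromatic ring for a six-membered one here; the two steps that bear on the ring nitrogen substituent are those to compound 3, where pyrimidin-2-yl entering lowered the maximal response modestly in both cases. Reversing a pyrimidin-2-yl toward another aromatic group is therefore expected to bring a modest rise in this assay, though the size of the step is uncertain. For compound 4 the estimate is 58%, within 42% to 74%, meaning an expected step of a number 9 percentage points higher from compound 3 to compound 4 (within the scatter).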

Compound 4, largest response reached (reported as efficacy), in percent of the reference or control that the assay uses: 44%
For compound 4 the middle estimate is 14 percentage points above the measured one; the range from low to high includes it.
By their numbers in this assay, from the lowest: compounds 4 and 3 (each within the scatter of the next); then compounds 2 and 1 (each within the scatter of the next).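

In this assay the first five-membered aromatic ring at this position sets itself apart from the six-membered pyrimidin-2-yl by no more than the scatter, with a number 5 percentage points lower from compound 3 to compound 4 (within the scatter) and the sulfur of 1,3-thiazol-2-yl in the ring. Set against the pyridine-bearing analogues, the drop is modest but clear, with a number 20 percentage points lower from compound 2 to compound 4 (beyond the scatter) and a number 26 percentage points lower from compound 1 to compound 4 (beyond the scatter) placing 1,3-thiazol-2-yl with pyrimidin-2-yl on the low side among these four compounds. Nothing at hand accounts for this grouping.

Still open, going by these compounds, is whether a plain phenyl or a 1,3-oxazol-2-yl on this ring nitrogen would fall with compound 1 and compound 2 or with compound 3 and compound 4. A nitrile on the 1,3-thiazol-2-yl ring is equally untested for any effect on the maximal response.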